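One Stereocentre Flipped in a Brominated Core

The source may report more compounds than this note shows. Statements on the series, on what has been measured and on what is new or still open speak of the compounds shown alone.

Compound 1 `C=C1C[C@@H](O)[C@@H](Br)C(C)(C)[C@@]12C=C[C@](O)(C(Br)Br)CC2` was tested in a functional assay on LNCaP cells (Homo sapiens) for cytotoxicity, read by resazurin assay; a higher number here means a weaker inhibitor, a lower number a stronger inhibitor. Compound 1 gives >= 10000 nM, which is a limit of the assay and not a number. Compound 2 `C=C1C[C@@H](O)[C@@H](Br)C(C)(C)[C@@]12C=C[C@](O)(CO)CC2` gives >= 10000 nM in this assay, again a limit. Compound 3 `CO[C@@]1(C)CC[C@]2(C[C@H]1Br)C(C)=C[C@H](O)CC2(C)C` gives >= 10000 nM in this assay, also a limit. The single step shown, a step that the two limits leave unreadable from compound 1 to compound 2, cannot be read because of the limit of >= 10000 nM in this assay, at which 3 of the 3 values shown sit. Compound 4 `C=C1C[C@@H](O)[C@@H](Br)C(C)(C)[C@@]12C=C[C@@](O)(C(Br)Br)CC2` differs from compound 1 only as follows: the two compounds have the same atoms and bonds and differ only in configuration as drawn: 1 of 4 stereo elements differ; a stereocentre at a saturated ring carbon is drawn S in compound 1 and R in compound 4. Within the data shown here, no measured step concerns a change of configuration alone, so nothing points in either direction. Compound 4 is therefore expected to give 10000 nM in this assay, somewhere between 5000 nM and 30000 nM, most probably again as a limit. The expected step of a number no higher from compound 1 to compound 4 (the limit leaves the size open) is estimated to be no step beyond the scatter.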

Compound 4, half-maximal inhibitory concentration: >= 10000 nM
Compound 4: no number, only a limit (the forecaster's own chance of this, stated with the estimate: 80%); the middle value sits exactly at the limit.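

The step from compound 1 to compound 4 cannot be read, because both compounds give only a limit: the limit of >= 10000 nM in this assay, at which 4 of the 4 values shown sit.

The compounds shown leave open whether flipping this one stereocentre changes the result at all in this assay.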